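Oxazole to imidazole on the ring-nitrogen methyl

The source may hold more compounds than are shown below. What is called first, only, known or untested is meant among the compounds shown, and "the series" means these compounds.

Measured compounds in an assay on isolated protein for activation of cGMP-dependent protein kinase 1 (Homo sapiens), read by ADP-Glo, with stated times of 120 min and 40 min; a higher number here means that more compound is needed for the effect, a lower number that less compound is needed:
compound 1 `COC(=O)Nn1c(C[C@H]2CCC[C@H](OCc3cc(C(F)(F)F)cc(C(F)(F)F)c3)[C@@H]2c2ccccc2)n[nH]c1=O` gives 4500 nM.
compound 2 `OC[C@@H](O[C@H]1CCCN(Cc2cccc3nonc23)[C@H]1c1ccccc1)c1cc(Cl)cc(Cl)c1` gives 8000 nM.
compound 3 `Clc1cc(Cl)cc(CO[C@H]2CCCN(Cc3ncco3)[C@H]2c2ccccc2)c1` gives only a limit, > 200000 nM.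

Compound 3 sits at the weak end of the three: its result in this assay is a limit of the assay and not a number, as the limit of > 200000 nM in this assay, at which 1 of the 3 values shown sits, records. Compound 1 and compound 2 both return numbers, and nothing connects them to compound 3 by a single change, so only their values stand for comparison.

Compound 4 `Clc1cc(Cl)cc(CO[C@H]2CCCN(Cc3ncc[nH]3)[C@H]2c2ccccc2)c1` differs from compound 3 at one point: 1H-imidazol-2-yl in place of 1,3-oxazol-2-yl on a saturated chain carbon bound to an amine nitrogen in a ring. The 1H-imidazol-2-yl carries a hydrogen-bond donor where the 1,3-oxazol-2-yl had none. For the measured compounds named here, no measured step of this kind is available, so the direction is open. The expectation is a step from compound 3 to compound 4 of an at least 1.3-fold lower number from compound 3 to compound 4 (0.12 log units; that floor lies within the scatter), which could well leave compound 4 also at the limit. Compound 4 is estimated at 150000 nM, in the range 30000 nM to 600000 nM.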

Compound 4, half-maximal effective concentration: 47000 nM
Beside the measured number, compound 4's estimate is 3.2-fold (0.50 log units) above it; the measured number falls inside the stated range.
By their numbers in this assay, from the lowest: compounds 1 and 2 (each within the scatter of the next); then compound 4. At a limit, above all of these: compound 3.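

In this assay, 1H-imidazol-2-yl in place of 1,3-oxazol-2-yl on a saturated chain carbon bound to an amine nitrogen in a ring gives an at least 4.2-fold lower number from compound 3 to compound 4 (0.62 log units; beyond the scatter). For the compounds shown here, this is the first single-place step, and it shows that this position responds to an exchange between two five-membered aromatic rings of equal heavy-atom count. The step is only a floor, as compound 3 gives a limit of the assay and not a number: the limit of > 200000 nM in this assay, at which 1 of the 4 values shown sits.

The compounds shown do not separate the entering hydrogen-bond donor from the exchange of oxygen for nitrogen in the ring, a question that a 1-methyl-1H-imidazol-2-yl group at the same place would bear on. Also open, as far as these compounds go, is how a 1,2,4-triazol-3-yl group would read there.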